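Removing one chloro group from compound 1

The source may report more compounds than this note shows. Statements on the series, on what has been measured and on what is new or still open speak of the compounds shown alone.

Among the compounds with values here, in a functional assay on A-375 cells (Homo sapiens) for inhibition, read by CCK-8 assay, with a stated time of 72 h (on this read-out higher numbers stand for weaker inhibition and lower numbers for stronger inhibition), compound 1 `O=C(NO)c1ccc(CNC(=O)c2n[nH]cc2NC(=O)c2c(Cl)cccc2Cl)cc1` gives 5050 nM, the highest number of the three measured so far, which makes it the weakest inhibitor of the set. Compound 2 `Nc1ccccc1NC(=O)c1ccc(CNC(=O)c2n[nH]cc2NC(=O)c2c(Cl)cccc2Cl)cc1` gives 1200 nM, and compound 3 `Nc1ccccc1NC(=O)c1ccc(CNC(=O)c2n[nH]cc2NC(=O)c2ccccc2F)cc1` gives 2270 nM.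

Compound 4 `O=C(NO)c1ccc(CNC(=O)c2n[nH]cc2NC(=O)c2ccccc2Cl)cc1` has not yet been measured. It differs from compound 1 by a single change, hydrogen in place of chloro on an aromatic carbon, which turns 2,6-dichlorophenyl into 2-chlorophenyl.

The closest evidence is a change at the same group, 2-fluorophenyl in place of 2,6-dichlorophenyl, which gave a 1.9-fold higher number from compound 2 to compound 3 (0.28 log units; within the scatter). That step was made on a different background, so it is only a rough guide. The other measured step, a 4.2-fold lower number from compound 1 to compound 2 (0.62 log units; beyond the scatter), lies elsewhere in the molecule and says little here. No change beyond the scatter is therefore expected, with a slight drift towards a higher number at most. The estimated step is a 1.2-fold higher number from compound 1 to compound 4 (0.07 log units; within the scatter). For compound 4 the expected value is 6000 nM, with an estimated range of 2800 nM to 12000 nM.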

Compound 4, half-maximal inhibitory concentration: 6420 nM
Estimate against measurement, compound 4: 1.1-fold (0.03 log units) below; measured number inside the range.
By their numbers in this assay, from the lowest: compounds 2 and 3 (each within the scatter of the next); then compounds 1 and 4 (each within the scatter of the next).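

Taking away one chloro group, so that 2,6-dichlorophenyl becomes 2-chlorophenyl, gives a 1.3-fold higher number from compound 1 to compound 4 (0.10 log units; within the scatter) in this assay. The earlier step from 2,6-dichlorophenyl to 2-fluorophenyl exchanged both chloro groups at once and sat on the 2-aminophenyl background, whereas this step alters a single chloro group on the background with hydroxy on the amide-type nitrogen, and it shows that on this background the read-out tolerates losing that group within the usual scatter. Nothing among the data given explains this result.

From the compounds shown here alone, it remains open whether the same removal would read the same way on the 2-aminophenyl background. Going by these compounds, it is also open what would follow if the remaining chloro group gave way to hydrogen, or if a methoxy group or an amine stood at this place on the ring.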